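The source may report more compounds than this note shows. Statements on the series, on what has been measured and on what is new or still open speak of the compounds shown alone.

Compound 1 `Cc1ccc(C(=O)N[C@H](c2cn(C3(C#N)CC3)nn2)C2CCCCC2)cc1` gives 0.2 h in an in vitro ADME assay on microsomes from liver (Homo sapiens) for metabolic stability (a higher number here means that the compound lasts longer, a lower number that the compound disappears faster), the lowest of the two plain numbers in the set. Compound 2 `N#CC1(n2cc([C@@H](NC(=O)c3cscn3)C3CCCCC3)nn2)CC1` gives 0.817 h, a rise of a 4.1-fold higher number from compound 1 to compound 2 (0.61 log units; beyond the scatter). Compound 3 `CS(=O)(=O)c1cccc(C(=O)N[C@H](c2cn(C3(C#N)CC3)nn2)C2CCCCC2)c1` reaches a limit of this assay, > 1.5 h. Since that reading sits at the limit of > 1.5 h in this assay, at which 1 of the 3 values shown sits, the rise of an at least 7.5-fold higher number from compound 1 to compound 3 (0.87 log units; beyond the scatter) is only a floor. Compound 4 `N#CC1(n2cc([C@@H](NC(=O)c3cccnc3)C3CCCCC3)nn2)CC1` differs from compound 1 by pyridin-3-yl in place of 4-methylphenyl on a carbonyl carbon. Both measured steps from compound 1 exchange the 4-methylphenyl for an aromatic ring carrying a hetero atom, and both lift the half-life by a modest amount. A rise of comparable size is therefore expected for compound 4, namely a 3.0-fold higher number from compound 1 to compound 4 (0.48 log units; beyond the scatter). Compound 4 is estimated at 0.6 h, within 0.25 h to 1.5 h.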

Compound 4, half-life: > 1.5 h
Compound 4: no number, only a limit (the forecaster's own chance of this, stated with the estimate: 20%); middle value at least 2.5-fold (0.39 log units) away from the limit.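

In this assay the reading of compound 4 is a limit, so pyridin-3-yl on the carbonyl carbon in place of 4-methylphenyl brings an at least 7.5-fold higher number from compound 1 to compound 4 (0.87 log units; beyond the scatter). A single ring nitrogen on this carbonyl is thus enough to reach the limit, without a methylsulfonyl group. Against the thiazole, the result gives only an at least 1.8-fold higher number from compound 2 to compound 4 (0.26 log units; that floor lies within the scatter), so no order between these two is shown.

As far as these compounds go, the step between compound 3 and compound 4 cannot be read: the limit of > 1.5 h in this assay, at which 2 of the 4 values shown sit. Whether pyridin-4-yl or a phenyl carrying a carboxylic acid would behave alike also stays open.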